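Adding an Amino Group Where the Signal Is Already Gone

The source may report more compounds than this note shows. Statements on the series, on what has been measured and on what is new or still open speak of the compounds shown alone.

Compound 1 `COc1ncnc2c1c(-c1ccsc1)cn2[C@@H]1O[C@H](CO)[C@@H](O)[C@H]1O` is the anchor of this small set. In a functional assay on HL-60 cells (Homo sapiens) for antiproliferative activity, read by XTT assay, with a stated time of 72 h (a higher number here means a weaker inhibitor, a lower number a stronger inhibitor), compound 1 gives 130 nM. Compound 2 `COc1nc(N)nc2c1c(-c1ccsc1)cn2[C@@H]1O[C@H](CO)[C@@H](O)[C@H]1O` differs from it in one place, (amino in place of hydrogen on an aromatic carbon). For compound 2 only a limit of this assay is known, > 20000 nM. The resulting step is an at least 150-fold higher number from compound 1 to compound 2 (2.18 log units; beyond the scatter).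

Compound 3 `O=c1[nH]cnc2c1c(-c1cc3ccccc3o1)cn2[C@@H]1O[C@H](CO)[C@@H](O)[C@H]1O` rests on a different core; the difference between the cores of compound 1 and compound 3 is not broken down here. For compound 3 only a limit is known in this assay, > 20000 nM. Compound 4 `Nc1nc2c(c(-c3cc4ccccc4o3)cn2[C@@H]2O[C@H](CO)[C@@H](O)[C@H]2O)c(=O)[nH]1` stands to compound 3 much as compound 2 stands to compound 1: amino in place of hydrogen on an aromatic carbon. The surroundings differ, since the carbon is here meta to a group of 1 heavy atom rather than meta to a methoxy group (2 heavy atoms), so this is the same kind of change rather than the same change. Compound 3 already sits at the limit of > 20000 nM in this assay, at which 2 of the 3 values shown sit, so a further loss could scarcely register, and the expected step is a step that the limit leaves unreadable from compound 3 to compound 4. Compound 4 is therefore expected to give 40000 nM, most probably reported again as a limit.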

Compound 4, half-maximal inhibitory concentration: > 20000 nM
Compound 4 ended at the assay's limit; the forecaster's own chance of this, stated with the estimate: 85%; the middle value is on the limit's open side.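

No step can be read from compound 3 to compound 4, since each is reported only as a limit and not as a number: the limit of > 20000 nM in this assay, at which 3 of the 4 values shown sit. The compounds shown leave open whether amino in place of hydrogen changes activity at all on the core of compound 3.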